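Indazole substituent changes on the acrylic acid scaffold

This account rests on a few compounds, and the source may have more. Where it says the series, first, only, none or still open, it means among the compounds named here.

Measured so far in a functional assay on MCF7 cells (Homo sapiens) for cytotoxicity, read by CellTiter-Glo, with a stated time of 5 days; a lower number here means a stronger inhibitor, a higher number a weaker inhibitor:
- compound 1 `CC/C(=C(/c1ccc(/C=C/C(=O)O)cc1)c1cnc2[nH]ncc2c1)c1ccccc1`: 302 nM
- compound 2 `CC/C(=C(/c1ccc(/C=C/C(=O)O)cc1)c1ccc2[nH]ncc2c1F)c1ccccc1`: 3 nM
- compound 3 `CC/C(=C(/c1ccc(/C=C/C(=O)O)cc1)c1cc2cn[nH]c2cc1Cl)c1ccccc1`: 137 nM

Compound 2 gives the lowest number of the three in this assay; its nearest neighbour is compound 3, a 46-fold higher number from compound 2 to compound 3 (1.66 log units; beyond the scatter), and the furthest is compound 1, a 100-fold lower number from compound 1 to compound 2 (2.00 log units; beyond the scatter). Compound 3 in turn improves on compound 1 only modestly, a 2.2-fold lower number from compound 1 to compound 3 (0.34 log units; beyond the scatter).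

Compound 4 `CC/C(=C(/c1ccc(/C=C/C(=O)O)cc1)c1ccc2[nH]ncc2c1C#N)c1ccccc1` is the next variation on compound 2. The change is cyano in place of fluoro on an aromatic carbon; in words, cyano in place of fluoro on an aromatic carbon, ortho to a fused ring and ortho to a large group.

Within the data shown here, no measured step isolates a substituent swap at this position. The step from compound 2 to compound 3 changes both the substituent and the attachment of the fused system, so it cannot be read as a guide to the cyano alone; the step from compound 1 to compound 2 changes the ring system itself. Both steps were large, which shows that this part of the molecule is sensitive to change. Without a direct precedent, the expectation is a moderate move upward from compound 2, a 4.0-fold higher number from compound 2 to compound 4 (0.60 log units; beyond the scatter), with wide uncertainty. Compound 4 is therefore expected to give about 12 nM in this assay, within 3 nM to 50 nM.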

Compound 4, half-maximal inhibitory concentration: 1.5 nM
Beside the measured number, compound 4's estimate is 8.0-fold (0.90 log units) above it; measured number below the stated range.
By their numbers in this assay, from the lowest: compounds 4 and 2 (each within the scatter of the next); then compound 3; then compound 1.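

In this assay, cyano in place of fluoro on this aromatic carbon, ortho to a fused ring and ortho to a large group, gives a 2.0-fold lower number from compound 2 to compound 4 (0.30 log units; within the scatter), so compound 2 and compound 4 cannot be told apart. This is the only step shown that isolates a substituent swap at this position, and it shows that the position accepts a cyano, with 1 hydrogen-bond acceptor, in place of a fluoro, with no acceptor, without a shift beyond the scatter; the sensitivity seen in the earlier large steps, which involved wider changes, does not appear for this swap. No measured evidence bears on why these two groups read alike.

Going by these compounds, whether this tolerance extends beyond cyano and fluoro stays open, and a methyl, a methoxy or an amine on the same carbon would test how far it reaches. Also open, on these data alone, is whether cyano would read the same way on the core of compound 1 or with the attachment of the fused system found in compound 3.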